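Removing the Isopropyl Branch from Compound 1

The source may hold more compounds than are shown below. What is called first, only, known or untested is meant among the compounds shown, and "the series" means these compounds.

Measured so far:
compound 1, `CC(=O)Nc1cccc(-c2ccc(C(O)(c3c[nH]cn3)C(C)C)cc2)c1`: 17 nM
compound 2, `CC(=O)Nc1cccc(-c2ccc([C@@](O)(c3c[nH]cn3)C(C)C)cc2)c1`: 770 nM
compound 3, `CC(C)C(O)(c1ccc(-c2ccccn2)cc1)c1c[nH]cn1`: 210 nM

All three were tested in an assay on microsomes from Testis (strain Sprague-Dawley) for inhibition of steroid 17-alpha-hydroxylase/17,20 lyase (Rattus norvegicus); on this read-out higher numbers stand for weaker inhibition and lower numbers for stronger inhibition. Compound 1 stands lowest of the three numbers, and its steps to both others lie beyond the scatter, so it is the strongest inhibitor here. The step of a 45-fold higher number from compound 1 to compound 2 (1.66 log units; beyond the scatter) is large; the two compounds share every atom and bond, and the fact that one of compounds 1 and 2 is drawn with a defined configuration and the other without, at the place where they differ is the only difference between them. Among the compounds with values here, compound 3 has no single-point step to compound 1, so only its value can be set beside that of compound 1.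

Compound 4, `CC(=O)Nc1cccc(-c2ccc(C(O)c3c[nH]cn3)cc2)c1`, has not yet been measured. It differs from compound 1 by hydrogen in place of isopropyl on a saturated chain carbon bound to two aromatic carbons and an oxygen on a saturated carbon. Within the data shown here, no measured step changes this position, so nothing among the known compounds anchors the size or direction of the effect; the change does sit at the same carbon whose drawn configuration separates compound 1 from compound 2, and compound 4, like compound 1, is drawn without one. A modest loss of inhibition is expected for compound 4, a step of a 7.1-fold higher number from compound 1 to compound 4 (0.85 log units; beyond the scatter). The expected value for compound 4 is 120 nM, within 25 nM to 600 nM.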

Compound 4, half-maximal inhibitory concentration: 320 nM
The estimate for compound 4 lay 2.7-fold (0.43 log units) below the measured number; measured number inside the range.
By their numbers in this assay, from the lowest: compound 1; then compounds 3 and 4 (each within the scatter of the next); then compound 2.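

In this assay, within the data shown here, the isopropyl group on this saturated chain carbon proves to matter: putting hydrogen in its place gives a 19-fold higher number from compound 1 to compound 4 (1.27 log units; beyond the scatter), a large loss of inhibition and the only measured change of group at this position. The earlier pair showed that this carbon responds to how its configuration is drawn, and this step adds that it also responds to what it carries, at least for this one swap. Nothing measured here accounts for the size of this step.

Going by these compounds, whether a methyl or an ethyl group on this carbon, or a cyclopropyl ring or a longer chain, would keep the inhibition seen with compound 1 remains open. Also open, on these data alone, is how compound 4 would behave with a defined configuration drawn at this carbon.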